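Adding a methoxy group on the shared core: two related steps

The source may hold more compounds than are shown below. What is called first, only, known or untested is meant among the compounds shown, and "the series" means these compounds.

Three compounds share one core and differ only in the methoxy groups on one aromatic ring. In a functional assay on SW-620 cells (Homo sapiens) for cytotoxicity, read by MTT assay, with a stated time of 72 h (a lower number here means a stronger inhibitor, a higher number a weaker inhibitor), compound 1 `COc1ccc(/C=C2\CCC/C(=C\c3cccc(OC)c3OC)C2=O)cc1` gives 13600 nM. Compound 2 `COc1ccc(/C=C2\CCC/C(=C\c3cccc(OC)c3OC)C2=O)c(OC)c1` reaches only a limit of this assay, > 20000 nM, because of the limit of > 20000 nM in this assay, at which 1 of the 3 values shown sits. The change between them is methoxy in place of hydrogen on an aromatic carbon, and it produced an at least 1.4-fold higher number from compound 1 to compound 2 (0.16 log units; that floor lies within the scatter). Compound 3 `COc1cc(/C=C2\CCC/C(=C\c3cccc(OC)c3OC)C2=O)cc(OC)c1` gives 3800 nM in this assay; how its core differs from that of compound 1 is not broken down here. Compound 4 `COc1cccc(/C=C2\CCC/C(=C\c3cc(OC)c(OC)c(OC)c3)C2=O)c1OC` is not yet measured. It differs from compound 3 by methoxy in place of hydrogen on an aromatic carbon, the same kind of change as from compound 1 to compound 2, but here ortho to two methoxy groups and para to a large group rather than ortho to a large group and meta to a methoxy group. Resting on compound 1 weakening to compound 2 by an at least 1.4-fold higher number from compound 1 to compound 2 (0.16 log units; that floor lies within the scatter), a step of a 1.6-fold higher number from compound 3 to compound 4 (0.20 log units; within the scatter) is expected. Compound 4 is therefore estimated at 6000 nM, between 2000 nM and 20000 nM.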

Compound 4, half-maximal inhibitory concentration: 2500 nM
Estimate against measurement, compound 4: 2.4-fold (0.38 log units) above; measured number inside the range.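

In this assay, a methoxy group in place of hydrogen, ortho to two methoxy groups, gives a 1.5-fold lower number from compound 3 to compound 4 (0.18 log units; within the scatter). Set beside the same kind of change on the other core, the two steps cannot be told apart: the same change on two cores in this assay, an at least 1.4-fold higher number (0.16 log units; that floor lies within the scatter) from compound 1 to compound 2 and a 1.5-fold lower number (0.18 log units; within the scatter) from compound 3 to compound 4; the limit leaves it open whether they differ Compound 2 gives > 20000 nM, which is a limit and not a number, and with it these two pairs neither show that the change carries over from one core to another nor show that it does not.

The compounds shown leave open what a different group at this place would do. An amine or a carboxylic acid, or a longer chain in place of methoxy, might move the number beyond the scatter.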